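Ortho substituent swap on the shared core: nitrile for alkyne

The source may report more compounds than this note shows. Statements on the series, on what has been measured and on what is new or still open speak of the compounds shown alone.

Measured compounds:
- compound 1, `Cn1cncc1C(OCc1ccc(C#N)cc1/C=C/c1ccc([N+](=O)[O-])cc1)c1ccc(C#N)cc1`: 2.24 nM
- compound 2, `Cn1cncc1C(OCc1ccc(C#N)cc1C#CC1(O)CCCCC1)c1ccc(C#N)cc1`: 1.93 nM

In a functional assay on NIH3T3 cells (Mus musculus) (on this read-out lower numbers stand for an effect already at smaller amounts and higher numbers for an effect only at larger amounts of compound), compound 1 gives 2.24 nM and compound 2 gives 1.93 nM. Among the measured compounds shown here, the only step measured so far, a 1.2-fold lower number from compound 1 to compound 2 (0.06 log units; within the scatter), exchanges one large group on an aromatic carbon for another without a change beyond the scatter, so compound 2 and compound 1 stand together within the usual scatter of this assay and no order between them can be read.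

Compound 3, `Cn1cncc1C(OCc1ccc(C#N)cc1-c1ccc(C#N)cc1)c1ccc(C#N)cc1`, has not been measured. The change from compound 2 is 4-cyanophenyl in place of 2-(1-hydroxycyclohexyl)ethynyl on an aromatic carbon. For the measured compounds named here, no measured step introduces a 4-cyanophenyl at this position, so the only guide is the step from compound 1 to compound 2, where a substantial change of the group at the same place left this assay unchanged within the scatter. On that basis no shift beyond the scatter is expected in this assay. The expected step is a 1.3-fold higher number from compound 2 to compound 3 (0.11 log units; within the scatter). Compound 3 is expected to give about 2.5 nM in this assay, with a range from 0.8 nM to 8 nM.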

Compound 3, half-maximal effective concentration: < 0.1 nM
Compound 3: a limit, no number (the forecaster's own chance of this, stated with the estimate: 3%); middle value at least 25-fold (1.39 log units) from the limit.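

Compound 1 and compound 2 stand within the scatter of each other, which left open whether this position responds to its substituent at all, but it does respond in this assay: with 4-cyanophenyl in place of 2-(1-hydroxycyclohexyl)ethynyl the series shows an at least 19-fold lower number from compound 2 to compound 3 (1.28 log units; beyond the scatter), and with 4-cyanophenyl in place of 2-(4-nitrophenyl)ethenyl it shows an at least 22-fold lower number from compound 1 to compound 3 (1.35 log units; beyond the scatter). The value of compound 3 is a limit of the assay and not a number, so both steps give only a minimum size: the limit of < 0.1 nM in this assay, at which 1 of the 3 values shown sits. Of the three groups, only 4-cyanophenyl has its ring directly on the aromatic carbon, with no ethenyl or ethynyl link, and across three compounds this remains an observation and not a rule.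

The compounds shown do not tell whether the large step goes with the directly attached ring or with the nitrile it carries, and the true value of compound 3 remains unknown. An unsubstituted phenyl, a 4-aminophenyl or a 4-carboxyphenyl group at the same place would separate the ring from its nitrile.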